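The source may hold more compounds than are shown below. What is called first, only, known or untested is meant among the compounds shown, and "the series" means these compounds.

Compound 1 `CC(C)(Oc1ccccc1Br)C1OCC(C/C=C\CCC(=O)O)C(c2cccnc2)O1`: 29 nM
Compound 2 `Cc1ccc(SC(C)(C)C2OCC(C/C=C\CCC(=O)O)C(c3cccnc3)O2)c([N+](=O)[O-])c1`: 30 nM

In an assay for inhibition of Thromboxane-A synthase (Homo sapiens), using microsomes (on this read-out lower numbers stand for stronger inhibition and higher numbers for weaker inhibition), compound 1 gives 29 nM. In this assay compound 2 gives 30 nM. Going by the values given here, compound 2 thus holds the highest of the two numbers, but the single measured step between the two, a 1.0-fold higher number from compound 1 to compound 2 (0.01 log units; within the scatter), means the two compounds cannot be told apart on this read-out. That step exchanged the whole aromatic group hanging from the saturated chain carbon without moving the number.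

Compound 3 `CC(C)(C1OCC(C/C=C\CCC(=O)O)C(c2cccnc2)O1)S(=O)(=O)c1ccccc1` has not yet been measured. It differs from compound 2 in one place: a group of 9 heavy atoms (6 carbon, 2 oxygen, 1 sulfur; one six-membered aromatic ring of carbon only) in place of a group of 11 heavy atoms (7 carbon, 1 nitrogen, 2 oxygen, 1 sulfur; one six-membered aromatic ring of carbon only), on a saturated chain carbon bound to two saturated chain carbons and a saturated ring carbon. Among the compounds with values here, the only step that bears on this change is a 1.0-fold higher number from compound 1 to compound 2 (0.01 log units; within the scatter), which concerns the same position and the same kind of exchange of an aromatic group. On that ground no step beyond the scatter is expected in this assay, though the phenylsulfonyl group resembles neither of the two groups already measured, so the range is kept wide. For compound 3 the estimate in this assay is 40 nM, between 12 nM and 130 nM, which corresponds to an expected step of a 1.3-fold higher number from compound 2 to compound 3 (0.12 log units; within the scatter).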

Compound 3, half-maximal inhibitory concentration: 40 nM
Estimate against measurement, compound 3: no gap at the digits printed; low and high end bracket the measured number.
By their numbers in this assay, from the lowest: compounds 1, 2 and 3 (each within the scatter of the next).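

In this assay, phenylsulfonyl on the saturated chain carbon gives a 1.3-fold higher number from compound 2 to compound 3 (0.12 log units; within the scatter), and in place of 2-bromophenoxy it gives a 1.4-fold higher number from compound 1 to compound 3 (0.14 log units; within the scatter). All three groups now read alike on this assay, even though phenylsulfonyl differs from the other two in its atoms and carries nothing on its aromatic ring besides the sulfonyl link, so a third, quite different aromatic group leaves the number within the scatter. Nothing available here accounts for this flat result, so the sameness of the numbers stands as an observation only.

The compounds shown leave open whether an aromatic ring is needed on this carbon at all, since each of the three groups carries one, and how a cyclohexyl ring, an amine or a carboxylic acid in that place would read is unknown. They also leave open how small the group can become before the number moves beyond the scatter, as a single methyl group would test.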